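The source may hold more compounds than are shown below. What is called first, only, known or untested is meant among the compounds shown, and "the series" means these compounds.

Compound 1 `C=C(C)[C@@H]1CC=C(Cn2cc(COc3ccc(C4NC(=O)NC(C)=C4C(=O)OCC)cc3)nn2)CC1` was tested in a functional assay on NCI-H460 cells (Homo sapiens) for inhibition, read by sulforhodamine B assay, with a stated time of 48 h; on this read-out higher numbers stand for weaker inhibition of growth and lower numbers for stronger inhibition of growth. In this assay compound 1 gives > 100000 nM, which is a limit of the assay and not a measured number. Compound 2 `C=C(C)[C@@H]1CC=C(Cn2cc(COc3ccc(C4NC(=O)NC(C)=C4C(=O)OCC)cc3OC)nn2)CC1` carries a methoxy in place of hydrogen on an aromatic carbon. In this assay compound 2 gives > 100000 nM, again only a limit. The step that the two limits leave unreadable from compound 1 to compound 2 therefore cannot be read because both values sit at the limit of > 100000 nM in this assay, at which 2 of the 2 values shown sit. Compound 3 `C=C(C)[C@@H]1CC=C(Cn2cc(COc3ccc(C4NC(=O)NC(C)=C4C(C)=O)cc3)nn2)CC1` differs from compound 1 by methyl in place of ethoxy on a carbonyl carbon. Going by the values given here, no measured step touches the carbonyl carbon, and the two limits give no direction, so the data set no size for this step beyond the usual scatter. The expected step of a number no higher from compound 1 to compound 3 (the limit leaves the size open) is accordingly no change beyond the scatter, with another limit the most likely outcome. For compound 3 the estimate in this assay is 100000 nM, ranging from 30000 nM to 300000 nM.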

Compound 3, concentration for total growth inhibition: 78200 nM
Compound 3: the middle estimate sits 1.3-fold (0.11 log units) above what was measured, and the stated range covers the measured number.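

In this assay, going by these compounds alone, the change from ethoxycarbonyl to acetyl gives the first step in this set with a direction: an at least 1.2-fold lower number from compound 1 to compound 3 (0.10 log units; that floor lies within the scatter). Compound 3 is also the only compound shown with a measured number, while the other two remain at a limit: the limit of > 100000 nM in this assay, at which 2 of the 3 values shown sit.

Going by these compounds, the true size of the step stays open upward, as only its floor can be read, and that floor lies within the usual scatter; the change on this carbonyl carbon may therefore be slight or much larger.

The compounds shown leave open how a carboxylic acid, a primary amide or a longer chain would read on this carbonyl carbon, and whether the loss of the ethoxy oxygen or the shorter group matters more. They also leave open what acetyl would give together with the methoxy of compound 2.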